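The source may hold more compounds than are shown below. What is called first, only, known or untested is meant among the compounds shown, and "the series" means these compounds.

Working notes on the series in an ADME assay on HEL cells (Homo sapiens) for cytotoxicity, with a stated time of 3 days; a higher number here means that more compound is tolerated, a lower number that less compound is tolerated.

Compound 1 `O=S1(=O)C=C(OCc2ccccc2)C(Cc2ccccc2)(Cc2ccccc2)O1` gives 200000 nM in this assay. Compound 3 `CC(C)CC1(Cc2ccccc2)OS(=O)(=O)C=C1OCc1ccccc1` returns only a limit of the assay, >= 80000 nM. The change from compound 1 to compound 3 is isopropyl in place of phenyl on a saturated chain carbon bound to a saturated ring carbon, and the step that the limit leaves unreadable from compound 1 to compound 3 is left without a readable size by the limit of >= 80000 nM in this assay, at which 1 of the 3 values shown sits.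

Compound 2 `CCC1(Cc2ccccc2)OS(=O)(=O)C=C1OCc1ccc(C)cc1` likewise returns only a limit of the assay, >= 16000 nM. Compound 2 therefore stands at a limit rather than at a number, and of the three values shown one further value is also a limit; the limit of >= 16000 nM in this assay, at which 1 of the 3 values shown sits, marks where compound 2 sits.

Compound 4 `CCC1(Cc2ccccc2)OS(=O)(=O)C=C1OCCc1ccccc1` differs from compound 2 as benzyl in place of 4-methylphenyl on a saturated chain carbon bound to an oxygen on an unsaturated carbon, the two having the same atoms joined differently. Going by the values given here, the single measured step, from compound 1 to compound 3, concerns another place and has no readable size, so no measured step bears on the change from compound 2 to compound 4. For compound 4 the expected step that the limit leaves unreadable from compound 2 to compound 4 is none beyond the scatter. Compound 4 is expected to return a limit again, as compound 2 did. Compound 4 is estimated at 50000 nM, with a range from 16000 nM to 200000 nM.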

Compound 4, minimum cytotoxic concentration: >= 20000 nM
Compound 4 gave a limit, no number (the forecaster's own chance of this, stated with the estimate: 70%); the middle value is on the limit's open side.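

In this assay compound 2 and compound 4 both return only limits of the assay, and no step can be read for the change from 4-methylbenzyl to phenethyl. The compounds shown leave open whether compound 2, compound 3 and compound 4 truly differ from one another or from compound 1, which alone gives a number, 200000 nM.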